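Swapping a Methoxy for a Bromo on an Inactive Scaffold

The compounds below may be only part of what the source reports. "The series", "measured", "known", "first", "only" and "open" are said of these compounds alone.

Compound 2, `COc1ccc(-n2ccc(=O)c(C(=O)Nc3ccc(Oc4ccnc5c4ccn5C)c(F)c3)n2)cc1`, has been tested in a functional assay on PC-3 cells (Homo sapiens) for cytotoxicity, read by MTT assay, with a stated time of 72 h; a higher number here means a weaker inhibitor, a lower number a stronger inhibitor. In this assay compound 2 gives > 60000 nM, which is a limit of the assay and not a number. Its chloro relative, compound 1, `Cn1ccc2c(Oc3ccc(NC(=O)c4nn(-c5ccc(Cl)cc5)ccc4=O)cc3F)ccnc21`, is also known. In this assay compound 1 gives > 60000 nM, again a limit rather than a number. The step that the two limits leave unreadable from compound 1 to compound 2 cannot be read, because both values sit at the limit of > 60000 nM in this assay, at which 2 of the 2 values shown sit.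

Compound 3, `Cn1ccc2c(Oc3ccc(NC(=O)c4nn(-c5ccc(Br)cc5)ccc4=O)cc3F)ccnc21`, has not yet been measured. It differs from compound 2 in one place: bromo in place of methoxy on an aromatic carbon. Going by the values given here, the only measured step that touches this position is the one from chloro to methoxy, and its size is not readable. With both known compounds at the limit, no shift beyond the scatter can be expected in either direction, and the most likely outcome is that the assay again reports only a limit. Compound 3 is therefore expected to give about 80000 nM, with a range from 30000 nM to 200000 nM. The change is estimated as a step that the limit leaves unreadable from compound 2 to compound 3, no real movement.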

Compound 3, half-maximal inhibitory concentration: > 60000 nM
Compound 3 gave a limit, no number; the forecaster's own chance of this, stated with the estimate: 85%; the middle value is on the limit's open side.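

Compound 3 sits with compound 1 and compound 2 at the same limit, which is not a number, so no step among these three compounds can be read in this assay: the limit of > 60000 nM in this assay, at which 3 of the 3 values shown sit.

The compounds shown leave open whether chloro, methoxy and bromo at this position differ at all in their effect on these cells.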